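Dimethyl piperidine variant of a triazine series with inactive members

The source may report more compounds than this note shows. Statements on the series, on what has been measured and on what is new or still open speak of the compounds shown alone.

The study concerns a set of compounds built on a shared core, tested in a functional assay on DU-145 cells (Homo sapiens) for cytotoxicity, read by sulforhodamine B assay, with a stated time of 48 h; on this read-out higher numbers stand for weaker inhibition of growth and lower numbers for stronger inhibition of growth. Compound 1, `N#Cc1ccc(Nc2nc(Oc3ccnc4ccccc34)nc(N3CCCCC3)n2)cc1C(F)(F)F`, carries a piperidin-1-yl group on that core. In this assay compound 1 gives > 100000 nM, which is a limit of the assay and not a number. Two further compounds share this standing. Compound 2, `COc1ccc(CN2CCN(c3nc(Nc4ccc(C#N)c(C(F)(F)F)c4)nc(Oc4ccnc5ccccc45)n3)CC2)c(OC)c1OC`, gives > 100000 nM in this assay, again a limit and not a number. Compound 3, `N#Cc1ccc(Nc2nc(Oc3ccnc4ccccc34)nc(N3CCN(c4ccc(F)cc4)CC3)n2)cc1C(F)(F)F`, gives > 100000 nM in this assay, once more a limit rather than a number. Going by the values given here, all three values thus sit at the limit of > 100000 nM in this assay, at which 3 of the 3 values shown sit, and no step between measured compounds can be drawn from them.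

Compound 4, `CC1CC(C)CN(c2nc(Nc3ccc(C#N)c(C(F)(F)F)c3)nc(Oc3ccnc4ccccc34)n2)C1`, has not yet been measured in this assay. Its difference from compound 1 is 3,5-dimethylpiperidin-1-yl in place of piperidin-1-yl on an aromatic carbon. Among the compounds with values here, with every measured compound resting at the limit, there is no measured step on which a change in either direction could be founded; the expectation is therefore for no step beyond the scatter, which means the estimated step of a number no higher from compound 1 to compound 4 (the limit leaves the size open). Compound 4 is accordingly expected to give about 100000 nM in this assay, within a range from 30000 nM to 300000 nM, with a high chance that only a limit is again reported.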

Compound 4, concentration for total growth inhibition: 68000 nM
Beside the measured number, compound 4's estimate is 1.5-fold (0.17 log units) above it, and the stated range covers the measured number.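

At this position on the shared core, 3,5-dimethylpiperidin-1-yl in place of piperidin-1-yl comes with an at least 1.4-fold lower number from compound 1 to compound 4 (0.16 log units; that floor lies within the scatter) in this assay. Compound 4 gives 68000 nM, the only actual number among the compounds shown, so this change at this position yields a value that can be read as a number, which none of the earlier compounds did. The step is only a floor, however, and it does not establish a change beyond the scatter, while the other compounds remain at the assay's limit: the limit of > 100000 nM in this assay, at which 3 of the 4 values shown sit.

The compounds shown leave open whether a single methyl group on the piperidine, as in 4-methylpiperidin-1-yl, would give a number in this assay, or whether both methyl groups are needed. They also leave open what a morpholin-4-yl group, a diethylamino group or a primary amine at the same position would give, and whether any such group would reach values well away from the limit.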